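This account rests on a few compounds, and the source may have more. Where it says the series, first, only, none or still open, it means among the compounds named here.

Values in a physicochemical assay for lipophilicity; on this read-out lower numbers stand for lower lipophilicity and higher numbers for higher lipophilicity:
- compound 1 `COc1ccc(C2C[C@@]3(ON2c2ccccc2)C(=O)O[C@@H]2[C@H]3CC[C@H](C)[C@]3(O)C=CC(=O)[C@@]23C)cc1`: 3.25
- compound 2 `Cc1ccccc1C1C[C@@]2(ON1c1ccccc1)C(=O)O[C@@H]1[C@H]2CC[C@H](C)[C@]2(O)C=CC(=O)[C@@]12C`: 3.64
- compound 3 `C[C@H]1CC[C@@H]2[C@@H](OC(=O)[C@]23CC(c2c(F)cccc2F)N(c2ccccc2)O3)[C@]2(C)C(=O)C=C[C@@]12O`: 3.42

Compound 3, at 3.42, lies within the scatter of both others, with a number 0.17 log units higher from compound 1 to compound 3 (within the scatter) and a number 0.22 log units lower from compound 2 to compound 3 (within the scatter). The next change gives compound 4 `C[C@H]1CC[C@@H]2[C@@H](OC(=O)[C@]23CC(c2cccc(Cl)c2)N(c2ccccc2)O3)[C@]2(C)C(=O)C=C[C@@]12O`, with 3-chlorophenyl in place of 2,6-difluorophenyl on a saturated ring carbon. Among the measured compounds shown here, no measured compound carries this group, so only the swaps at this carbon bear on it. The largest of these is a number 0.39 log units higher from compound 1 to compound 2 (beyond the scatter), and the direct comparison a number 0.22 log units lower from compound 2 to compound 3 (within the scatter) is smaller. In this assay, a small rise and no step beyond the scatter is expected, the estimated step being a number 0.18 log units higher from compound 3 to compound 4 (within the scatter). Compound 4 is estimated at 3.6, within a range of 3.3 to 3.95.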

Compound 4, partition coefficient: 3.87
Estimate against measurement, compound 4: 0.27 log units below; low and high end bracket the measured number.
By their numbers in this assay, from the lowest: compounds 1, 3, 2 and 4 (each within the scatter of the next, the first and the last beyond it).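

In this assay the 3-chlorophenyl group shows a number 0.45 log units higher from compound 3 to compound 4 (beyond the scatter) and so separates from 2,6-difluorophenyl at this saturated ring carbon, which 4-methoxyphenyl did not do. The widest span at this carbon so far is a number 0.62 log units higher from compound 1 to compound 4 (beyond the scatter) and it sets the two aryl groups furthest apart, while a number 0.23 log units higher from compound 2 to compound 4 (within the scatter) leaves 3-chlorophenyl unresolved from 2-methylphenyl. Nothing available accounts for these steps.

Open, as far as these compounds go, is whether an amine or a carboxylic acid on the aryl ring at this carbon would fall outside this span. Also open, from the compounds shown here alone, is how a change to the phenyl group on the ring nitrogen would read.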